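The source may hold more compounds than are shown below. What is called first, only, known or untested is meant among the compounds shown, and "the series" means these compounds.

Measured so far:
compound 1, `Nc1ccccc1NC(=O)c1ccc(NC(=S)NCc2cncc(Br)c2)cc1`: 7500 nM
compound 2, `Nc1ccccc1NC(=O)c1ccc(NC(=O)NCc2ccc(Cl)nc2)cc1`: 2400 nM
compound 3, `Nc1ccccc1NC(=O)c1ccc(Cn2cc(-c3ccc(NC(=O)NCc4cccnc4)cc3)nn2)cc1`: 8100 nM

All three were read in a functional assay on HepG2 cells (Homo sapiens) for cytotoxicity, read by MTT assay, with a stated time of 72 h; on this read-out lower numbers stand for stronger inhibition and higher numbers for weaker inhibition. Compound 1 stands second highest of the three numbers. Its nearest neighbour is compound 3, whose number lies within the scatter of that of compound 1, so no order between these two can be read. Compound 2 gives a number lower than that of compound 1, beyond the scatter. The next compound, compound 4 with structure `Nc1ccccc1NC(=O)c1ccc(NC(=S)NCc2cccc(F)c2)cc1`, differs from compound 1 in one place: 3-fluorophenyl in place of 5-bromopyridin-3-yl on a saturated chain carbon bound to an amide-type nitrogen. For the measured compounds named here, no measured pair shows this change, so nothing beyond the scatter is expected in either direction. Compound 4 is thus expected to give 6000 nM, with a range from 2500 nM to 14000 nM, meaning an expected step of a 1.3-fold lower number from compound 1 to compound 4 (0.10 log units; within the scatter).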

Compound 4, half-maximal inhibitory concentration: 2900 nM
Compound 4: middle estimate off by 2.1-fold (0.32 log units), on the high side; low and high end bracket the measured number.
By their numbers in this assay, from the lowest: compounds 2 and 4 (each within the scatter of the next); then compounds 1 and 3 (each within the scatter of the next).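

For the compounds shown here, replacing 5-bromopyridin-3-yl with 3-fluorophenyl gives, in this assay, a 2.6-fold lower number from compound 1 to compound 4 (0.41 log units; beyond the scatter), the first single-place step, so the group on this saturated chain carbon does shift the number, if only modestly. The ring nitrogen and the bromine leave together, and this one pair cannot assign the step to either. Nothing measured here bears on the reason for the step.

Still open, going by these compounds, is whether plain phenyl or 3-bromophenyl would read with compound 4 or with compound 1. Also open, on these data alone, is how an amine on this ring, or a longer chain before it, would read.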